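The compounds below may be only part of what the source reports. "The series", "measured", "known", "first", "only" and "open" are said of these compounds alone.

Measured so far: compound 1 `Cc1ccccc1S(=O)(=O)NC(=O)c1ccc(Nc2nc(NC3(c4ccc(Cl)cc4)CC3)nc(OCC(F)(F)F)n2)cc1` gives 100% in an ADME assay on microsomes from liver (Rattus norvegicus) for metabolic stability, with a stated time of 10 min; on this read-out lower numbers stand for a less stable compound and higher numbers for a more stable compound; compound 2 `CCS(=O)(=O)NC(=O)c1ccc(Nc2nc(NC3(c4ccc(Cl)cc4)CC3)nc(OCC(F)(F)F)n2)cc1` gives 85% in this assay.

Compound 2 holds the lowest of the two numbers, and its nearest neighbour is compound 1, separated by a number 15 percentage points lower from compound 1 to compound 2 (beyond the scatter). Compound 3 `CC(=O)NCCS(=O)(=O)NC(=O)c1ccc(Nc2nc(NC3(c4ccc(Cl)cc4)CC3)nc(OCC(F)(F)F)n2)cc1` differs from compound 2 by acetamido in place of hydrogen on a saturated chain carbon, two bonds along the chain from a sulfonyl sulfur. For the measured compounds named here, the only measured step, a number 15 percentage points lower from compound 1 to compound 2 (beyond the scatter), concerns the group on the sulfonyl sulfur itself, not a substituent on the chain, so it offers no direct guide. Going by the values given here, with no precedent for this change, compound 3 is expected to show a step of a number 3 percentage points lower from compound 2 to compound 3 (within the scatter) in this assay, within the scatter. Compound 3 is therefore estimated at 82%, in the range 60% to 98%.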

Compound 3, percent of the compound remaining: 100%
Compound 3: middle estimate off by 18 percentage points, on the low side; measured number outside the range, above it.
By their numbers in this assay, from the lowest: compound 2; then compounds 1 and 3 (each within the scatter of the next).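

In this assay, acetamido on the saturated chain carbon, two bonds along the chain from a sulfonyl sulfur, gives a number 15 percentage points higher from compound 2 to compound 3 (beyond the scatter) and so is tolerated at this position with no loss on this read-out. Putting 2-acetamidoethyl in place of 2-methylphenyl on the sulfonyl sulfur gives no change at the digits printed from compound 1 to compound 3 (within the scatter) here, so the 2-methylphenyl group is not needed to hold this number. No supporting data shown here explain the rise.

On these data alone, it remains open whether an amine or a carboxylic acid on the same chain carbon would match acetamido. As far as these compounds go, it is also open whether a longer chain carrying the acetamido group would behave as 2-acetamidoethyl does.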